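Chlorine Added Ortho on Two Different Acid Cores

The source may hold more compounds than are shown below. What is called first, only, known or untested is meant among the compounds shown, and "the series" means these compounds.

Compound 1 `O=C(O)C1CCN(c2ccccc2Cl)C1` gives 19000 nM in an assay on cells for inhibition of Palmitoleoyl-protein carboxylesterase NOTUM variant C330S (Homo sapiens), read by fluorescence, with a stated time of 40 min; a lower number here means a stronger inhibitor, a higher number a weaker inhibitor.
Compound 2 `Cc1cc(C(=O)O)c(C)n1-c1ccc(Cl)cc1` gives 860 nM in this assay.
Compound 3 `Cc1cc(C(=O)O)c(C)n1-c1ccc(Cl)cc1Cl` gives 430 nM in this assay.

Compound 1 stands highest of the three numbers, beyond the scatter from both compound 2 and compound 3. How the core of compound 1 differs from the shared core of compound 2 and compound 3 is not broken down here.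

Compound 2 and compound 3 differ by one change, (chloro in place of hydrogen on an aromatic carbon), which gave a 2.0-fold lower number from compound 2 to compound 3 (0.30 log units; within the scatter). Compound 4 `O=C(O)C1CCN(c2cccc(Cl)c2Cl)C1`, not yet measured, carries the same kind of change on compound 1: chloro in place of hydrogen on an aromatic carbon. The surroundings are not identical, since in compound 3 the new chloro group sits ortho to a large group and meta to a chloro group, while in compound 4 it sits ortho to a chloro group and meta to a group of 8 heavy atoms.

With a single prior example, and that one within the scatter, the expected step for compound 4 in this assay is modest, a 2.0-fold lower number from compound 1 to compound 4 (0.30 log units; within the scatter), resting on compound 3 and its step of a 2.0-fold lower number from compound 2 to compound 3 (0.30 log units; within the scatter). Compound 4 is therefore estimated at 9500 nM, likely between 4000 nM and 25000 nM.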

Compound 4, half-maximal inhibitory concentration: 8000 nM
The estimate for compound 4 lay 1.2-fold (0.07 log units) above the measured number, and the stated range covers the measured number.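

In this assay, the added chloro group gave a 2.4-fold lower number from compound 1 to compound 4 (0.38 log units; beyond the scatter). Set beside the earlier case, the same change pointed the same way on both cores, and the two steps cannot be told apart: the same change on two cores in this assay, a 2.0-fold lower number (0.30 log units; within the scatter) from compound 2 to compound 3 and a 2.4-fold lower number (0.38 log units; beyond the scatter) from compound 1 to compound 4, 1.2-fold (0.07 log units) apart, within the scatter of two such steps. Among the compounds shown here, this agreement rests on only two pairs, one of them within the scatter, and the new chloro group stands in different surroundings on each core, so it does not show that the step would hold on another core or at another place on the aromatic ring.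

The compounds shown leave open whether a different group in the same place, such as fluoro, methyl or methoxy, would move the number in the same way on both cores. They also leave open what would follow if the carboxylic acid carried by all four compounds gave way to a primary amide.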